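A few compounds are considered here, and "the series" means these few. Any claim that something is new, unique, unknown or untested is made for them only; others in the source may bear on it.

Measured so far:
compound 1 `Cc1nc(N(C)C(=O)NC(=O)c2c(F)cccc2F)sc1C(=O)N/N=C/c1ccc(C(F)(F)F)cc1`: 30.6 ug/mL
compound 2 `CN(C(=O)NC(=O)c1ccc([N+](=O)[O-])cc1)c1nc(C(F)(F)F)c(C(=O)N/N=C/c2cccc(C(F)(F)F)c2)s1`: 4.39 ug/mL

In a functional assay on MCF7 cells (Homo sapiens) for inhibition, read by MTT assay, with a stated time of 72 h (a lower number here means a stronger inhibitor, a higher number a weaker inhibitor), compound 1 gives 30.6 ug/mL, the highest of the two numbers. Compound 2 gives 4.39 ug/mL, a lower number, and the gap between the two lies beyond the scatter. Compound 2 differs from compound 1 in several places at once, so the pair says nothing about any single change.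

Compound 3 `Cc1nc(N(C)C(=O)NC(=O)c2c(F)cccc2F)sc1C(=O)N/N=C/c1ccccc1C(F)(F)F` has not been measured. It has the same atoms as compound 1, joined differently: 2-(trifluoromethyl)phenyl in place of 4-(trifluoromethyl)phenyl on a carbon with a double bond to nitrogen. Among the compounds with values here, no measured pair isolates a change of this kind, so the expectation rests on the two numbers alone. A rearrangement of one substituent on the same aromatic ring, with nothing else altered, is expected to shift this assay by at most a small step, in no firm direction, and likely within the scatter. Compound 3 is therefore estimated near compound 1, at 25 ug/mL with a range from 10 ug/mL to 60 ug/mL. The expected step of a 1.2-fold lower number from compound 1 to compound 3 (0.09 log units; within the scatter) is small.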

Compound 3, half-maximal inhibitory concentration: 7.34 ug/mL
Estimate against measurement, compound 3: 3.4-fold (0.53 log units) above; the whole stated range lies above it.
By their numbers in this assay, from the lowest: compounds 2 and 3 (each within the scatter of the next); then compound 1.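

With the rest of compound 1 held fixed, 2-(trifluoromethyl)phenyl in place of 4-(trifluoromethyl)phenyl on a carbon with a double bond to nitrogen gives a 4.2-fold lower number from compound 1 to compound 3 (0.62 log units; beyond the scatter) in this assay. Within the data shown here, this is the only single-place comparison so far, and it shows that rearranging the same atoms at this position is enough to move the read-out, with the counts of heavy atoms, donors and acceptors unchanged. Nothing available explains the shift.

As far as these compounds go, it remains open whether a nitrile or a carboxylic acid in place of trifluoromethyl on this aromatic ring would give a comparable number in this assay. Compound 2 differs from compound 3 in several places, so it cannot show whether this step carries over to other groups on the shared core.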